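Fluorine for pentafluorosulfanyl on the thioether and sulfone arms

The compounds below may be only part of what the source reports. "The series", "measured", "known", "first", "only" and "open" are said of these compounds alone.

The series rests on two cores. Compound 1 `CC(O)(CSc1ccc(S(F)(F)(F)(F)F)cc1)C(=O)Nc1ccc(S(F)(F)(F)(F)F)cc1` carries a thioether link and gives 24400 nM in a functional assay on CWR22R cells (Homo sapiens) for antiproliferative activity, read by propidium iodide staining, with a stated time of 96 h; a lower number here means a stronger inhibitor, a higher number a weaker inhibitor. Compound 2 `CC(O)(CSc1ccc(F)cc1)C(=O)Nc1ccc(S(F)(F)(F)(F)F)cc1` differs from it by one fluorine atom in place of a group of 6 heavy atoms (5 fluorine, 1 sulfur; no ring), on an aromatic carbon and gives 13500 nM in this assay; the step of a 1.8-fold lower number from compound 1 to compound 2 (0.26 log units; within the scatter). Compound 3 `CC(O)(CS(=O)(=O)c1ccc(S(F)(F)(F)(F)F)cc1)C(=O)Nc1ccc(S(F)(F)(F)(F)F)cc1` carries a sulfone link in place of the thioether; how its core differs from that of compound 1 is not broken down here. In this assay compound 3 gives 17300 nM, which sits close to the values of compound 1 and compound 2.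

Compound 4 `CC(O)(CS(=O)(=O)c1ccc(F)cc1)C(=O)Nc1ccc(S(F)(F)(F)(F)F)cc1` is not yet measured. It differs from compound 3 by one fluorine atom in place of a group of 6 heavy atoms (5 fluorine, 1 sulfur; no ring), on an aromatic carbon, the same change that turns compound 1 into compound 2, made at the same place. Because the step of a 1.8-fold lower number from compound 1 to compound 2 (0.26 log units; within the scatter) stayed within the scatter, compound 4 is expected to follow compound 3 by a step of similar size, a 1.6-fold lower number from compound 3 to compound 4 (0.20 log units; within the scatter). The account therefore estimates compound 4 at 11000 nM in this assay, with a likely span from 5000 nM to 25000 nM.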

Compound 4, half-maximal inhibitory concentration: 20600 nM
For compound 4 the middle estimate is 1.9-fold (0.27 log units) below the measured one; measured number inside the range.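

In this assay the exchange of pentafluorosulfanyl for fluorine on the sulfone core gives a 1.2-fold higher number from compound 3 to compound 4 (0.08 log units; within the scatter), and setting this step beside the one on the thioether core shows no measurable difference between the cores: the same change on two cores in this assay, a 1.8-fold lower number (0.26 log units; within the scatter) from compound 1 to compound 2 and a 1.2-fold higher number (0.08 log units; within the scatter) from compound 3 to compound 4, 2.2-fold (0.33 log units) apart, within the scatter of two such steps On both cores, then, the exchange leaves the number within the scatter, and nothing in these four compounds marks it as behaving differently from one core to the other. This does not show that the change has an effect of a fixed size that carries across the series, since neither step can be told from the scatter and two cores are a narrow base.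

The compounds shown leave open how the same exchange would behave with a sulfoxide or an ether link in place of the thioether and the sulfone. They also leave open what a nitrile or a trifluoromethyl group would do at that aromatic carbon, or in place of the pentafluorosulfanyl group on the amide side.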